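Swapping methyl for methoxy on the benzylamine arm

The source may report more compounds than this note shows. Statements on the series, on what has been measured and on what is new or still open speak of the compounds shown alone.

Compound 2 `COc1cc(/C=C/c2nc(NCc3ccc(C)cc3)c3sccc3n2)cc(OC)c1OC` gives 2930000 nM in an ADME assay on L02 cells (Homo sapiens) for cytotoxicity, read by MTT assay (a lower number here means a stronger inhibitor, a higher number a weaker inhibitor), the highest of the two numbers recorded; its closest neighbour is compound 1 `COc1cc(/C=C/c2nc(NCc3ccccc3)c3sccc3n2)cc(OC)c1OC`, which gives 1800000 nM. Among the compounds with values here, the only measured step, a 1.6-fold higher number from compound 1 to compound 2 (0.21 log units; within the scatter), lay within the scatter. Compound 3 `COc1ccc(CNc2nc(/C=C/c3cc(OC)c(OC)c(OC)c3)nc3ccsc23)cc1` carries methoxy in place of methyl on an aromatic carbon. Within the data shown here, that earlier step is the sole guide here, and it was small, so nothing beyond the scatter is expected. The step of a 1.0-fold lower number from compound 2 to compound 3 (0.00 log units; within the scatter) is thus expected to stay within the scatter. Compound 3 is therefore estimated at 2900000 nM, within a range from 1200000 nM to 7000000 nM.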

Compound 3, half-maximal inhibitory concentration: 2050000 nM
Compound 3: the middle estimate sits 1.4-fold (0.15 log units) above what was measured; the range from low to high includes it.
By their numbers in this assay, from the lowest: compounds 1, 3 and 2 (each within the scatter of the next).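

Methoxy brings a hydrogen-bond acceptor to this aromatic carbon, where methyl has none, yet the change gives a 1.4-fold lower number from compound 2 to compound 3 (0.16 log units; within the scatter) in this assay. Set against hydrogen at the same carbon, methoxy gives a 1.1-fold higher number from compound 1 to compound 3 (0.06 log units; within the scatter), so hydrogen, methyl and methoxy at this place cannot be told apart in this read-out. No evidence at hand bears on this result. The compounds shown leave open whether an amine or a carboxylic acid on this carbon would move the number beyond the scatter. They also leave open whether a longer chain there would do so.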